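Pyridin-4-yl in place of the aryl carbonyl

The compounds below may be only part of what the source reports. "The series", "measured", "known", "first", "only" and "open" are said of these compounds alone.

Within the data shown here, compound 1 `CC1(C)C=C(n2ccccc2=O)c2cc(C(=O)c3ccc(O)cc3)ccc2O1` shows the higher of the two numbers so far in a functional assay (trachea) with Rattus norvegicus as the target (on this read-out higher numbers stand for higher potency (the scale is a negative logarithm) and lower numbers for lower potency), giving 5.87; compound 2 `CC1(C)C=C(n2ccccc2=O)c2cc(C(=O)c3ccccc3C(F)(F)F)ccc2O1` gives 5.78, and the step of a number 0.09 log units lower from compound 1 to compound 2 (within the scatter) lies within the scatter. Compound 3 `CC1(C)C=C(n2ccccc2=O)c2cc(-c3ccncc3)ccc2O1` differs from compound 1 by pyridin-4-yl in place of (4-hydroxyphenyl)carbonyl on an aromatic carbon. Among the measured compounds shown here, the only measured step bears on it loosely: exchanging the aryl on the carbonyl moved nothing beyond the scatter, and no step removes the carbonyl itself. A modest drop is therefore expected, a number 0.27 log units lower from compound 1 to compound 3 (within the scatter), with wide uncertainty. Compound 3 is estimated at 5.6, range 4.9 to 6.3.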

Compound 3, logarithm of the reciprocal of the active concentration, log(1/C): 6.32
Beside the measured number, compound 3's estimate is 0.72 log units below it, and the stated range ends below it.
By their numbers in this assay, from the lowest: compounds 2 and 1 (each within the scatter of the next); then compound 3.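

In this assay, among these compounds, a number 0.45 log units higher from compound 1 to compound 3 (beyond the scatter), the first step beyond the scatter, so a carbonyl is not required on this aromatic carbon: pyridin-4-yl, attached directly, serves at least as well as the (4-hydroxyphenyl)carbonyl group. This single change removes the carbonyl and the hydroxyl and brings in a ring nitrogen, so the step cannot be assigned to any one of these. Nothing available explains the step.

As far as these compounds go, it remains open whether the rise follows the ring nitrogen or the loss of the carbonyl. A plain phenyl or a pyridin-4-ylcarbonyl group at this place would separate the two.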